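This account rests on a few compounds, and the source may have more. Where it says the series, first, only, none or still open, it means among the compounds named here.

Measured so far in an ADME assay on MT4 cells (Homo sapiens) for cytotoxicity, read by MTT assay; a higher number here means that more compound is tolerated, a lower number that less compound is tolerated:

Compound 1, `O=C(CSc1nncnc1-c1ccccc1Cl)N1CCc2ccccc2C1`, gives >= 38000 nM, which is a limit of the assay rather than a number.
Compound 2, `O=C(CSc1nncnc1-c1cccc2ccccc12)Nc1ccc([N+](=O)[O-])cc1Cl`, gives 150000 nM.
Compound 3, `O=C(CSc1nncnc1-c1ccccc1Cl)Nc1ccccn1`, gives 172000 nM.

Among the two numbers, compound 2 stands lowest, yet compound 3 sits within the usual scatter of it, so the two cannot be told apart. The one limit is described by the limit of >= 38000 nM in this assay, at which 1 of the 3 values shown sits.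

Compound 4, `Cc1ccccc1NC(=O)CSc1nncnc1-c1cccc2ccccc12`, has not been measured. It differs from compound 2 in one place: 2-methylphenyl in place of 2-chloro-4-nitrophenyl on an amide-type nitrogen. No pair of measured compounds shows such a change, so the direction of the step in this assay is open; a step of no more than the scatter is expected, since both numbers shown lie close together. Compound 4 is estimated at 140000 nM, between 50000 nM and 300000 nM, meaning an expected step of a 1.1-fold lower number from compound 2 to compound 4 (0.03 log units; within the scatter).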

Compound 4, half-maximal cytotoxic concentration: 158000 nM
Compound 4: middle estimate off by 1.1-fold (0.05 log units), on the low side, and the stated range covers the measured number.
By their numbers in this assay, from the lowest: compounds 2, 4 and 3 (each within the scatter of the next).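

In this assay, among these compounds, the step at this amide-type nitrogen, a 1.1-fold higher number from compound 2 to compound 4 (0.02 log units; within the scatter), gives the first direct reading of a change at this position. Replacing 2-chloro-4-nitrophenyl with the smaller 2-methylphenyl, which has no hydrogen-bond acceptors, leaves the tolerated concentration indistinguishable. Nothing shown here accounts for this.

This is a single pair, and every group shown at this position contains an aromatic ring. As far as these compounds go, a saturated chain ending in an amine or a carboxylic acid on this nitrogen could behave differently, so how far this tolerance extends remains open.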